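From Thiophene Amide to a Second Aryl Sulfonamide

The source may hold more compounds than are shown below. What is called first, only, known or untested is meant among the compounds shown, and "the series" means these compounds.

Three compounds have been examined in an ADME assay on FHC cells (Homo sapiens) for cytotoxicity, read by resazurin assay, with a stated time of 48 h; a higher number here means that more compound is tolerated, a lower number that less compound is tolerated. Compound 1 `O=C(Nc1ccc(Sc2nc3ccccc3s2)c(Cl)c1)c1cccc(Br)c1O` gives only a limit of the assay, > 100000 nM. Compound 2 `COc1ccc(S(=O)(=O)Nc2ccc3oc(-c4ccc(NC(=O)c5ccc(Cl)s5)cc4)nc3c2)cc1` also gives only a limit, > 100000 nM. Within the data shown here, compound 3 `O=S(=O)(Nc1ccc(-c2nc3cc(NS(=O)(=O)c4cccc(C(F)(F)F)c4)ccc3o2)cc1)c1cccc(C(F)(F)F)c1`, the one compound with two sulfonyl groups, gives a number, 56000 nM. Compound 2 therefore stands at the limit of > 100000 nM in this assay, at which 2 of the 3 values shown sit, and no number separates it from compound 1.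

Compound 4 `COc1ccc(S(=O)(=O)Nc2ccc(-c3nc4cc(NS(=O)(=O)c5ccc(OC)cc5)ccc4o3)cc2)cc1` has not yet been measured in this assay. It differs from compound 2 in one place: (4-methoxyphenyl)sulfonyl in place of (5-chlorothiophen-2-yl)carbonyl on a nitrogen on an aromatic ring. Among the measured compounds shown here, no measured pair differing in a single place is available, so the size of this step cannot be read from a measured one. Compound 2 sits at a limit. Compound 3, which also carries two sulfonyl groups, gives 56000 nM. On that basis the step of an at least 1.1-fold lower number from compound 2 to compound 4 (0.04 log units; that floor lies within the scatter) is expected to stay within the usual scatter, in either direction. Compound 4 is accordingly estimated to give 90000 nM, with a range from 40000 nM to 200000 nM, and a limit rather than a number is quite likely.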

Compound 4, half-maximal cytotoxic concentration: 57000 nM
Beside the measured number, compound 4's estimate is 1.6-fold (0.20 log units) above it, within the range that was stated.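

In this assay, the change on this nitrogen on an aromatic ring can now be read as a step: an at least 1.7-fold lower number from compound 2 to compound 4 (0.24 log units; that floor lies within the scatter). Among these compounds, with (4-methoxyphenyl)sulfonyl in place of (5-chlorothiophen-2-yl)carbonyl, the position gives a number rather than a limit of the assay, so this change has a measured end point for the first time. The step still has only a floor and no exact size: the limit of > 100000 nM in this assay, at which 2 of the 4 values shown sit.

The compounds shown do not separate the effect of replacing the carbonyl with a sulfonyl from that of replacing the 5-chlorothiophen-2-yl ring with the 4-methoxyphenyl ring. From the compounds shown here alone, how an amine or a carboxylic acid in place of the (4-methoxyphenyl)sulfonyl group would read in this assay also remains open.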